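The compounds below may be only part of what the source reports. "The series", "measured", "known", "first", "only" and "open" are said of these compounds alone.

Compound 1 `CCN(CC)c1ccc2cc(C(=O)c3ccc(N4CCN(C(=O)CN5CCN(C(=O)CCl)CC5)CC4)cc3)oc2c1`, in a functional assay on A549 cells (Homo sapiens) for cytotoxicity, read by MTT assay, with a stated time of 48 h; on this read-out lower numbers stand for stronger inhibition and higher numbers for weaker inhibition: 3060 nM
Compound 2 `CCN(CC)c1ccc2cc(C(=O)c3ccc(N4CCN(C(=O)CN5CCN(S(=O)(=O)C6CC6)CC5)CC4)cc3)oc2c1`: 17300 nM
Compound 3 `CCN(CC)c1ccc2cc(C(=O)c3ccc(N4CCN(C(=O)CN5CCN(S(=O)(=O)c6ccc(C#N)cc6)CC5)CC4)cc3)oc2c1`: only a limit, > 40000 nM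

Compound 2 has the highest number of the two numbers shown; compound 3 gives only a limit (the limit of > 40000 nM in this assay, at which 1 of the 3 values shown sits). Compound 4 `CCN(CC)c1ccc2cc(C(=O)c3ccc(N4CCN(C(=O)CN5CCN(CC(C)=O)CC5)CC4)cc3)oc2c1` differs from compound 2 in one place: 2-oxopropyl in place of cyclopropylsulfonyl on an amine nitrogen in a ring. Among the compounds with values here, no measured step covers 2-oxopropyl itself. The steps that touch the same ring nitrogen are a 5.7-fold higher number from compound 1 to compound 2 (0.75 log units; beyond the scatter) and an at least 2.3-fold higher number from compound 2 to compound 3 (0.36 log units; beyond the scatter), both pointing away from the two sulfonyl groups, and the carbonyl-bearing compound 1 sits lowest. A lower number than compound 2 is therefore expected for compound 4, by a modest step, a 1.9-fold lower number from compound 2 to compound 4 (0.28 log units; within the scatter), though the uncertainty is wide. Compound 4 is estimated at 9000 nM, ranging from 3000 nM to 30000 nM.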

Compound 4, half-maximal inhibitory concentration: 8920 nM
Compound 4: middle estimate off by 1.0-fold (0.00 log units), on the high side; the measured number falls inside the stated range.
By their numbers in this assay, from the lowest: compound 1; then compounds 4 and 2 (each within the scatter of the next). At a limit, above all of these: compound 3.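

At this ring nitrogen, 2-oxopropyl in place of cyclopropylsulfonyl gives a 1.9-fold lower number from compound 2 to compound 4 (0.29 log units; within the scatter), so the two groups are not told apart in this assay. Set against the other two groups, the same 2-oxopropyl gives an at least 4.4-fold lower number from compound 3 to compound 4 (0.65 log units; beyond the scatter) and a 2.9-fold higher number from compound 1 to compound 4 (0.46 log units; beyond the scatter), which shows that a group without sulfonyl need not sit as high as (4-cyanophenyl)sulfonyl, while (chloromethyl)carbonyl keeps the lowest number. Compound 3 gives only a limit: the limit of > 40000 nM in this assay, at which 1 of the 4 values shown sits.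

An acetyl group on this nitrogen would tell whether the chlorine accounts for that remaining gap. On these data alone, how an amine or a carboxylic acid at the end of a longer chain would read here stays open.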